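The source may hold more compounds than are shown below. What is called first, only, known or untested is meant among the compounds shown, and "the series" means these compounds.

Three closely related compounds have already been tested. Compound 1, `N=C(NCCCc1c[nH]cn1)NCCSC(c1ccccc1)c1ccccn1`, compound 2, `Cc1ccc(C(CC/N=C(\N)NCCCc2c[nH]cn2)c2ccccn2)cc1`, and compound 3, `N=C(NCCCc1c[nH]cn1)NCCC(c1ccc(Br)cc1)c1ccccn1`, share the same core and differ only in the aryl groups carried on the saturated chain. In a functional assay on cardiac atrium for agonist activity at histamine H2 receptor (Cavia porcellus) (on this read-out lower numbers stand for smaller maximal responses and higher numbers for larger maximal responses), compound 1 gives 1, compound 2 gives 1, and compound 3 gives 1. Compound 3 therefore stands level with compounds 1 and 2 at the digits recorded: its nearest neighbour is compound 1, with no change at those digits, and even its furthest, compound 2, shows no change beyond the scatter. Across these three compounds the maximal response does not move.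

Compound 4, `N=C(NCCCc1c[nH]cn1)NCCC(c1ccccn1)c1cccs1`, has not yet been measured in this assay. Relative to compound 3 it carries one change, (thiophen-2-yl in place of 4-bromophenyl on a saturated chain carbon bound to an aromatic carbon and a saturated chain carbon). Since the three aryl variations already examined all leave the maximal response unchanged, the step of no change at the digits printed from compound 3 to compound 4 (within the scatter) is expected to be none beyond the scatter, in either direction. On that basis compound 4 is estimated to reach 1 in this assay, with a range from 0.85 to 1.1, because compound 3 gives 1 and compounds 1 and 2 show the same.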

Compound 4, intrinsic activity: the largest response reached, as a fraction of the reference agonist's: 1
Compound 4: middle estimate and measured number agree at the digits printed, within the range that was stated.
By their numbers in this assay, from the lowest: compounds 1, 2, 3 and 4 (each within the scatter of the next).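

In this assay, putting thiophen-2-yl in place of 4-bromophenyl on a saturated chain carbon bound to an aromatic carbon and a saturated chain carbon gives no change at the digits printed from compound 3 to compound 4 (within the scatter). For the compounds shown here, this is the first comparison here between two compounds that differ in one place, so the level values of the earlier compounds can now be tied to a single exchange: a five-membered aromatic ring with 1 hetero atom stands where a six-membered aromatic ring of carbon only stood, sulfur enters, bromine leaves, and the maximal response stays level. Nothing available explains why the response holds through this exchange.

As far as these compounds go, all four compounds keep an aromatic ring at this place, so it remains open whether a cyclohexyl group, a methyl group or an amine there would hold the maximal response in this assay. Since every compound shown stands level, they also leave open which group at this place, if any, would bring the response down, and they say nothing about how much of each compound is needed to reach it.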